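Tosyl for thienoyl on the amine nitrogen of compound 2

This account rests on a few compounds, and the source may have more. Where it says the series, first, only, none or still open, it means among the compounds named here.

Measured compounds:
compound 1, `CCCCCCCCNC(=O)[C@@H](NC(=O)c1cccs1)[C@@H](C)O`, 149000 nM
compound 2, `CCCCCCCCCCCCCCNC(=O)[C@@H](NC(=O)c1cccs1)[C@@H](C)O`, 88400 nM
compound 3, `CCCCCCCCCCCCCCNC(=O)[C@@H](NC(=O)c1cc2ccccc2n1C)[C@@H](C)O`, 34500 nM

All three were read in a functional assay on HepG2 cells (Homo sapiens) for cytotoxicity, read by MTT assay, with a stated time of 48 h; a lower number here means a stronger inhibitor, a higher number a weaker inhibitor. Compound 2 sits between the other two numbers: the step of a 1.7-fold lower number from compound 1 to compound 2 (0.23 log units; within the scatter) is within the scatter, whereas a 2.6-fold lower number from compound 2 to compound 3 (0.41 log units; beyond the scatter) is beyond it.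

Compound 4, `CCCCCCCCCCCCCCNC(=O)[C@@H](NS(=O)(=O)c1ccc(C)cc1)[C@@H](C)O`, is not yet measured. It differs from compound 2 by (4-methylphenyl)sulfonyl in place of (thiophen-2-yl)carbonyl on an amine nitrogen. Going by the values given here, no measured step changes the carbonyl to a sulfonyl, so only the step from compound 2 to compound 3 bears on it loosely: there a larger aromatic group on the same carbonyl gave a 2.6-fold lower number from compound 2 to compound 3 (0.41 log units; beyond the scatter), a modest change. The present change is of a different kind, and the direction is not settled by the data; a step of similar or smaller size, in either direction, is expected in this assay. For compound 4 the estimate is 60000 nM, with a range from 20000 nM to 180000 nM. This estimate corresponds to a 1.5-fold lower number from compound 2 to compound 4 (0.17 log units; within the scatter).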

Compound 4, half-maximal inhibitory concentration: 10900 nM
For compound 4 the middle estimate is 5.5-fold (0.74 log units) above the measured one; measured number below the stated range.
By their numbers in this assay, from the lowest: compound 4; then compound 3; then compounds 2 and 1 (each within the scatter of the next).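

In this assay, replacing (thiophen-2-yl)carbonyl with (4-methylphenyl)sulfonyl on the amine nitrogen gives an 8.1-fold lower number from compound 2 to compound 4 (0.91 log units; beyond the scatter), larger than the step seen with an aromatic exchange on the carbonyl, a 2.6-fold lower number from compound 2 to compound 3 (0.41 log units; beyond the scatter). This position therefore accepts a sulfonyl in place of the carbonyl without loss, and compound 4 at 10900 nM has the lowest number of the series, below compound 3 at 34500 nM. No available evidence accounts for the size of this step.

The sulfonyl and the 4-methylphenyl ring enter together, so their shares remain unseparated; 4-methylbenzoyl or thiophen-2-ylsulfonyl on the same nitrogen would divide them. Going by these compounds, it also remains open whether the gain carries over to the octyl chain of compound 1.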